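Pyrrolidinyl for methyl on the pyridine of compound 1

A few compounds are considered here, and "the series" means these few. Any claim that something is new, unique, unknown or untested is made for them only; others in the source may bear on it.

Measured so far:
Compound 1 `Cc1cc(-c2noc([C@H](C)NC(=O)c3cc(C(F)(F)F)nn3C)n2)ccn1`: 165 nM
Compound 2 `C[C@H](NC(=O)c1cc(C(F)(F)F)nn1C)c1nc(-c2ccccn2)no1`: > 30000 nM
Compound 3 `C[C@H](NC(=O)c1cc(C(F)(F)F)nn1C)c1nc(-c2cnn(C)c2)no1`: 2640 nM

Of the compounds shown here, three sharing one core have been tested in an assay on T-REx-293 cells for inhibition of potassium channel subfamily T member 1 (Homo sapiens), read by patch clamp; a higher number here means a weaker inhibitor, a lower number a stronger inhibitor. Compound 1 gives the lowest of the two numbers, with compound 3 the nearest at 2640 nM. For compound 2 the assay reports only a limit, > 30000 nM, and that is all that is known of it (the limit of > 30000 nM in this assay, at which 1 of the 3 values shown sits). Swapping the whole aryl group thus moves the read-out a great deal: an at least 180-fold higher number from compound 1 to compound 2 (2.25 log units; beyond the scatter), and a 16-fold higher number from compound 1 to compound 3 (1.20 log units; beyond the scatter).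

The new compound 4 `C[C@H](NC(=O)c1cc(C(F)(F)F)nn1C)c1nc(-c2ccnc(N3CCCC3)c2)no1` keeps the pyridine of compound 1 and changes only its substituent: pyrrolidin-1-yl in place of methyl on an aromatic carbon. Within the data shown here, none of the measured steps touches this spot; all three replace the entire aromatic group, so they show only that this region is sensitive, not how a larger substituent on the retained pyridine would fare. Among the measured compounds shown here, with no direct precedent, the expectation is a modest move in either direction, within or near the scatter.

Compound 4 is therefore estimated at 250 nM in this assay, with a range of 50 nM to 1500 nM, which corresponds to an expected step of a 1.5-fold higher number from compound 1 to compound 4 (0.18 log units; within the scatter).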

Compound 4, half-maximal inhibitory concentration: 573 nM
Compound 4: middle estimate off by 2.3-fold (0.36 log units), on the low side, within the range that was stated.
By their numbers in this assay, from the lowest: compound 1; then compound 4; then compound 3. At a limit, above all of these: compound 2.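

In this assay, replacing only the substituent on the retained pyridine gives a 3.5-fold higher number from compound 1 to compound 4 (0.54 log units; beyond the scatter), a smaller move than the one seen when the whole aromatic group is exchanged, a 16-fold higher number from compound 1 to compound 3 (1.20 log units; beyond the scatter). Among these compounds, this is the first reading at this spot, next to the ring nitrogen, and it shows that the position accepts pyrrolidin-1-yl, with five heavy atoms in place of the single carbon of methyl, at a modest but real cost that lies beyond the scatter rather than with a loss of the kind that follows a change of the whole aromatic group. Nothing measured here accounts for this step, so its origin stays unexplained.

From the compounds shown here alone, with a single pair at this position, it remains open whether the step follows the ring of pyrrolidin-1-yl or its nitrogen: a cyclopentyl group would keep the ring with carbon in place of that nitrogen, and a dimethylamino group would keep the nitrogen without the ring. How a morpholin-4-yl group, or a plain hydrogen in place of methyl, would fare at this spot is also unknown from the compounds shown.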